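The source may report more compounds than this note shows. Statements on the series, on what has been measured and on what is new or still open speak of the compounds shown alone.

Compound 2 `CCN(CC)CCCCCCOc1ccc2oc(-c3ccccc3)cc(=O)c2c1` gives 100 nM in an assay on isolated protein (Cavia porcellus) with Sigma non-opioid intracellular receptor 1 (Homo sapiens) as the target, read by radioligand binding (on this read-out lower numbers stand for stronger inhibition and higher numbers for weaker inhibition), and compound 1 `CN(C)CCCCCCCCOc1ccc2oc(-c3ccccc3)cc(=O)c2c1` gives 143 nM; the step of a 1.4-fold lower number from compound 1 to compound 2 (0.16 log units; within the scatter) leaves the two within the scatter of each other. Compound 3 `O=c1cc(-c2ccccc2)oc2ccc(OCCCCCCN3CCNC(CCO)C3)cc12` differs from compound 2 by 3-(2-hydroxyethyl)piperazin-1-yl in place of diethylamino on a saturated chain carbon, six bonds along the chain from an oxygen on an aromatic ring. Among the measured compounds shown here, only the single step from compound 1 to compound 2 touches the same place, and it was small, so a change of the amine there has so far moved little. For the measured compounds named here, the entering group is larger and ring-bearing, for which no step exists. Compound 3 is therefore expected near compound 2, with a step of a 1.6-fold higher number from compound 2 to compound 3 (0.20 log units; within the scatter), giving an estimated 160 nM (range 50 nM to 500 nM).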

Compound 3, half-maximal inhibitory concentration: 94 nM
Compound 3: the middle estimate sits 1.7-fold (0.23 log units) above what was measured, within the range that was stated.
By their numbers in this assay, from the lowest: compounds 3, 2 and 1 (each within the scatter of the next).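

In this assay, among the compounds shown here, the step of a 1.1-fold lower number from compound 2 to compound 3 (0.03 log units; within the scatter) shows that a ring-bearing amine, 3-(2-hydroxyethyl)piperazin-1-yl, stands level with diethylamino at this place, where the earlier compounds offered only open-chain amines. The step of a 1.5-fold lower number from compound 1 to compound 3 (0.18 log units; within the scatter) likewise leaves it level with 2-(dimethylamino)ethyl, so all three amines lie within the scatter. Nothing at hand accounts for this result. Open, from the compounds shown here alone, is whether morpholine or a carboxylic acid in place of the amine would also stay level with diethylamino. Also open, going by these compounds, is whether 3-(2-hydroxyethyl)piperazin-1-yl would hold on a shorter chain.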